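Trading hydroxy for fluoro on compound 3

A few compounds are considered here, and "the series" means these few. Any claim that something is new, unique, unknown or untested is made for them only; others in the source may bear on it.

In a functional assay on HL-60 cells (Homo sapiens) for cytotoxicity, read by WST assay, with a stated time of 48 h (a lower number here means that less compound is needed, a higher number that more compound is needed for the effect), compound 3 `Oc1ccc(C[C@H]2COC[C@@H]2Cc2ccc(Cl)c(Cl)c2)cc1` gives 31000 nM, level with compound 2 `Oc1cccc(C[C@H]2COC[C@@H]2Cc2ccc(Cl)c(Cl)c2)c1` at 31000 nM. Compound 1 `Fc1ccccc1C[C@H]1COC[C@@H]1Cc1ccc(Cl)c(Cl)c1` gives 51000 nM, within the scatter of both. The next compound, compound 4 `Fc1ccc(C[C@H]2COC[C@@H]2Cc2ccc(Cl)c(Cl)c2)cc1`, has fluoro in place of hydroxy on an aromatic carbon. Compound 1 also carries a fluoro, so the closest measured comparison is a 1.6-fold lower number from compound 1 to compound 3 (0.22 log units; within the scatter). The two hydroxy compounds offer a second one, no change at the digits printed from compound 2 to compound 3 (within the scatter). Neither step leaves the scatter, so no step beyond the scatter is expected in this assay. The expected step is a 1.3-fold higher number from compound 3 to compound 4 (0.11 log units; within the scatter). For compound 4 the estimated value is 40000 nM, with an expected range of 20000 nM to 80000 nM.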

Compound 4, half-maximal effective concentration: 43000 nM
Compound 4: the middle estimate sits 1.1-fold (0.03 log units) below what was measured, within the range that was stated.
By their numbers in this assay, from the lowest: compounds 2, 3, 4 and 1 (each within the scatter of the next).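

In this assay, the direct exchange on the aromatic carbon gives a 1.4-fold higher number from compound 3 to compound 4 (0.14 log units; within the scatter), so replacing hydroxy with fluoro, which has no hydrogen-bond donor or acceptor, leaves the result within the scatter. The two wider comparisons, a 1.4-fold higher number from compound 2 to compound 4 (0.14 log units; within the scatter) and a 1.2-fold lower number from compound 1 to compound 4 (0.07 log units; within the scatter), also stay within the scatter, so neither the group nor its place on the phenyl ring separates these four compounds here. No measurement at hand explains this result. Still open, on these data alone, is whether an amine, a carboxylic acid or a longer chain at this position would produce a step beyond the scatter.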